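Aryl amine swap on the shared core: compound 2 to compound 3

The source may report more compounds than this note shows. Statements on the series, on what has been measured and on what is new or still open speak of the compounds shown alone.

For the measured compounds named here, the series so far holds two measured compounds. Compound 1 `C#CCSc1nc(Nc2ccc(OC)cc2)c(C#N)c(-c2ccccc2)n1` gives 28400 nM in a functional assay on MGC-803 cells (Homo sapiens) for inhibition, read by MTT assay, with a stated time of 72 h; a lower number here means a stronger inhibitor, a higher number a weaker inhibitor. Compound 2 `N#Cc1c(Nc2cccc(Cl)c2)nc(SCc2cn(Cc3ccccc3Cl)nn2)nc1-c1ccccc1` gives 15800 nM in this assay, the lower of the two numbers, though compound 1 sits close enough that the gap lies within the scatter of repeated measurements, so no order between the two can be claimed.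

Compound 3 `Cc1ccc(Nc2nc(SCc3cn(Cc4ccccc4Cl)nn3)nc(-c3ccccc3)c2C#N)cc1` has not yet been measured. It departs from compound 2 in one place (4-methylphenyl in place of 3-chlorophenyl on a nitrogen on an aromatic ring). Both groups are the same in size, ring count and donor and acceptor count. Going by the values given here, no step between two measured compounds follows a change of this kind, so there is no measured guide for its effect.

The expectation is that the step of a 1.1-fold lower number from compound 2 to compound 3 (0.02 log units; within the scatter) stays within the scatter. Compound 3 is therefore estimated at 15000 nM, with a range from 6000 nM to 40000 nM.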

Compound 3, half-maximal inhibitory concentration: 7190 nM
Compound 3: middle estimate off by 2.1-fold (0.32 log units), on the high side, within the range that was stated.
By their numbers in this assay, from the lowest: compound 3; then compounds 2 and 1 (each within the scatter of the next).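

Placing 4-methylphenyl in place of 3-chlorophenyl on the nitrogen gives a 2.2-fold lower number from compound 2 to compound 3 (0.34 log units; beyond the scatter) in this assay, a modest step and the only one in the series that can be read so far. It shows that the number responds to this aryl amine position even when the ring is kept. The two groups match in heavy atom count, ring, donors and acceptors, so those counts do not separate them, and nothing measured here explains the step.

The change alters both the substituent and its place on the ring, so a single step cannot show which of the two matters. A 4-chlorophenyl group on the same nitrogen would separate them, while a benzyl group would test whether the ring must sit directly on that nitrogen.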